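The compounds below may be only part of what the source reports. "The series", "measured", "known", "first", "only" and "open" are said of these compounds alone.

Within the data shown here, in an assay on cell membranes from spleen (Cavia porcellus) for binding affinity to leukotriene B4 receptor 1 (Homo sapiens) (a higher number here means a weaker inhibitor, a lower number a stronger inhibitor), compound 2 `O=C(O)CCCCCOc1cc(-c2ccccc2)cc(-c2ccccc2)n1` gives 3 nM and stands lowest of the three numbers so far. Its nearest neighbour is compound 3 `O=C(O)CCCCCOc1cc(-c2ccc(C(F)(F)F)cc2)cc(-c2ccccc2)n1`, which in this assay gives 10 nM; the step of a 3.3-fold higher number from compound 2 to compound 3 (0.52 log units; beyond the scatter) is beyond the scatter. Furthest away is compound 1 `COC(=O)CCCCCOc1cc(-c2ccccc2)cc(-c2ccccc2)n1`, which in this assay gives 40 nM; the step of a 13-fold lower number from compound 1 to compound 2 (1.12 log units; beyond the scatter) is large and well beyond the scatter.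

Compound 4 `NC(=O)CCCCCOc1cc(-c2ccccc2)cc(-c2ccccc2)n1` has not yet been measured in this assay. It differs from compound 2 by amino in place of hydroxy on a carbonyl carbon. Among the measured compounds shown here, the step that bears on it most directly is the one from compound 1 to compound 2, where the ester was replaced by the free acid on the same carbonyl and the number fell by a large margin: a 13-fold lower number from compound 1 to compound 2 (1.12 log units; beyond the scatter). Compound 4 keeps a hydrogen-bond donor on the carbonyl carbon but loses the hydroxy of the acid, so the expected change is a rise, though plausibly smaller than the ester step. The step from compound 2 to compound 3 concerns a different part of the molecule and gives no further guidance.

On this basis compound 4 is estimated at 20 nM in this assay, between 6 nM and 70 nM, an expected step of a 6.7-fold higher number from compound 2 to compound 4 (0.82 log units; beyond the scatter).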

Compound 4, half-maximal inhibitory concentration: 160 nM
For compound 4 the middle estimate is 8.0-fold (0.90 log units) below the measured one; measured number outside the range, above it.
By their numbers in this assay, from the lowest: compound 2; then compound 3; then compound 1; then compound 4.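

At the carbonyl carbon that closes the saturated chain, swapping hydroxy for amino in this assay gives a 53-fold higher number from compound 2 to compound 4 (1.73 log units; beyond the scatter), a change that matches the two groups in heavy atoms, hydrogen-bond donors and net charge as counted from the structures, and so shows that those counts alone do not keep the number low. The earlier compounds showed only that the methyl ester stands well above the free acid; the amide now stands higher still, with a 4.0-fold higher number from compound 1 to compound 4 (0.60 log units; beyond the scatter), so that among these three end groups the order runs from the acid through the ester to the amide, and the amide hydrogen does not give compound 4 a number nearer that of compound 2. No measurement available here accounts for this order.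

From the compounds shown here alone, how a tetrazole, a sulfonic acid or an N-methyl amide would stand at this carbonyl position remains open, and so does whether a shorter or longer chain would change the gap between acid and amide. Going by these compounds, it is also open whether the amide would rank the same way on the trifluoromethyl-bearing core of compound 3.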